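This account rests on a few compounds, and the source may have more. Where it says the series, first, only, none or still open, it means among the compounds named here.

The three compounds measured so far in a functional assay on MCF7 cells (Homo sapiens) for antiproliferative activity, read by MTT assay, with a stated time of 48 h; a higher number here means a weaker inhibitor, a lower number a stronger inhibitor:
compound 1 `COc1cc(-c2nnc3c(OC)cc(-c4ccc5[nH]ccc5c4)cn23)cc(OC)c1OC` gives 80 nM;
compound 2 `COc1cc(-c2nnc3c(OC4COC4)cc(-c4ccc5[nH]ccc5c4)cn23)cc(OC)c1OC` gives 2470 nM;
compound 3 `COc1cc(-c2nnc3c(OC4CC4)cc(-c4ccc5[nH]ccc5c4)cn23)cc(OC)c1OC` gives 259 nM.

Compound 1 stands lowest of the three, that is the strongest inhibitor here, and both other numbers lie beyond the usual scatter from it. The unmeasured compound 4 `COc1cc(-c2nnc3c(OC4CN(C(C)(C)C)C4)cc(-c4ccc5[nH]ccc5c4)cn23)cc(OC)c1OC` differs from compound 1 in one place: 1-(tert-butyl)azetidin-3-yl in place of methyl on an oxygen on an aromatic ring. Both measured steps bear on exactly this oxygen. Putting cyclopropyl in place of methyl there gave a 3.2-fold higher number from compound 1 to compound 3 (0.51 log units; beyond the scatter), while putting oxetan-3-yl there gave a 31-fold higher number from compound 1 to compound 2 (1.49 log units; beyond the scatter); the two rings themselves differ by a 9.5-fold lower number from compound 2 to compound 3 (0.98 log units; beyond the scatter), so the choice of ring at this oxygen matters strongly. The group entering in compound 4 is again a small ring, this time bearing a tert-butyl group on its nitrogen, which neither earlier ring carried. A large step toward a weaker inhibitor is therefore expected, in the direction and of roughly the size seen with oxetan-3-yl. Compound 4 is expected to give about 2000 nM, with a range from 500 nM to 8000 nM. This estimate means an expected step of a 25-fold higher number from compound 1 to compound 4 (1.40 log units; beyond the scatter).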

Compound 4, half-maximal inhibitory concentration: > 10000 nM
Compound 4 was reported as a limit; the forecaster's own chance of this, stated with the estimate: 5%; middle value at least 5.0-fold (0.69 log units) away from the limit.
By their numbers in this assay, from the lowest: compound 1; then compound 3; then compound 2. At a limit, above all of these: compound 4.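

The value for compound 4 in this assay is a limit, not a number: the limit of > 10000 nM in this assay, at which 1 of the 4 values shown sits.

Even so, the bulkiest group shown at this oxygen gives the poorest result, with an at least 120-fold higher number from compound 1 to compound 4 (2.09 log units; beyond the scatter) and an at least 38-fold higher number from compound 3 to compound 4 (1.58 log units; beyond the scatter). Oxetan-3-yl had been the poorest group at this place, yet there is an at least 4.0-fold higher number from compound 2 to compound 4 (0.60 log units; beyond the scatter), so a small ring on this oxygen can cost still more than the earlier compounds showed, and the order of the groups now runs methyl, cyclopropyl, oxetan-3-yl, 1-(tert-butyl)azetidin-3-yl.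

As far as these compounds go, it stays open whether the loss belongs to the azetidine ring or to the tert-butyl group on its nitrogen, which a plain azetidin-3-yl or an N-methyl azetidine would help to separate. From the compounds shown here alone, how an ethyl group or an open-chain amine on this oxygen would behave also stays open.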